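The source may report more compounds than this note shows. Statements on the series, on what has been measured and on what is new or still open speak of the compounds shown alone.

Measured compounds in a functional assay on cells for agonist activity at Free fatty acid receptor 1 (Mus musculus), read by FLIPR and calcium flux, with a stated time of 100 s; on this read-out lower numbers stand for an effect already at smaller amounts and higher numbers for an effect only at larger amounts of compound:

Compound 1 `O=C(O)C[C@@H]1CCN1c1ccc(OCc2ccc(Cl)cc2Cl)cc1` gives 440 nM.
Compound 2 `Cc1ccccc1COc1ccc(N2CCC[C@H]2CC(=O)O)cc1` gives 3400 nM.
Compound 3 `O=C(O)C[C@@H]1CCCN1c1ccc(Oc2ccc(Cl)cc2Cl)cc1` gives 3200 nM.

Compound 3 sits second highest of the three numbers. Its nearest neighbour is compound 2, and the step of a 1.1-fold lower number from compound 2 to compound 3 (0.03 log units; within the scatter) lies within the scatter, so the two are not told apart here. Compound 1 stands furthest from compound 3 and gives the clearly lower number of the set, but compound 1 and compound 3 differ in more than one place, so that gap cannot be tied to a single change.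

Compound 4 `O=C(O)C[C@@H]1CCCN1c1ccc(Oc2ccc(Cl)cc2)cc1` is not yet measured. It differs from compound 3 by hydrogen in place of chloro on an aromatic carbon, the 2,4-dichlorophenyl read as 4-chlorophenyl. Going by the values given here, no measured step touches this change: the only single-place step, from compound 2 to compound 3, swaps the whole aryl group and says nothing about one chloro group. Loss of a chloro group on an aryl ether of this kind is expected to cost some potency, so compound 4 is estimated at 6000 nM, within 2500 nM to 15000 nM, the expected step being a 1.9-fold higher number from compound 3 to compound 4 (0.27 log units; within the scatter).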

Compound 4, half-maximal effective concentration: > 33000 nM
Compound 4 ended at the assay's limit (the forecaster's own chance of this, stated with the estimate: 10%); at least 5.5-fold (0.74 log units) between middle value and limit.
By their numbers in this assay, from the lowest: compound 1; then compounds 3 and 2 (each within the scatter of the next). At a limit, above all of these: compound 4.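

In this assay the value of compound 4 is a limit of the assay and not a number: the limit of > 33000 nM in this assay, at which 1 of the 4 values shown sits.

The step is an at least 10-fold higher number from compound 3 to compound 4 (1.01 log units; beyond the scatter) and shows that hydrogen in place of chloro, on the aromatic carbon ortho to a large group and meta to a chloro group, is not a neutral change in this series, something the earlier swap of the whole aryl group, a 1.1-fold lower number from compound 2 to compound 3 (0.03 log units; within the scatter) and so not told apart, could not show. The 4-chlorophenyl group also separates from the 2-methylbenzyl group, with an at least 9.7-fold higher number from compound 2 to compound 4 (0.98 log units; beyond the scatter) as the step, so 4-chlorophenyl falls clearly short of both groups it was compared with.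

As far as these compounds go, whether another group at this place, such as fluoro or methoxy, could stand in for the chloro group stays open. Also open, from the compounds shown here alone, is how far compound 4 lies past its limit.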